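The source may hold more compounds than are shown below. What is called first, only, known or untested is meant among the compounds shown, and "the series" means these compounds.

In a functional assay on Huh-7 cells (Homo sapiens) for antiproliferative activity, read by CCK-8 assay, with a stated time of 72 h (on this read-out lower numbers stand for stronger inhibition of growth and higher numbers for weaker inhibition of growth), compound 1 `CCC1C(=O)N(C)c2cnc(Nc3ccc(S(=O)(=O)NC)cc3)nc2N1c1ccn(C)n1` gives 11900 nM and compound 2 `CCC1C(=O)N(C)c2cnc(-n3ccc4cc(C(=O)NC(C)C)ccc43)nc2N1c1ccn(C)n1` gives 6740 nM on the same read-out. These two numbers lie within the usual scatter of each other, so compound 2 stands level with compound 1. Compound 3 `CCC1C(=O)N(C)c2cnc(-n3ccc4cc(C(N)=O)ccc43)nc2N1c1ccn(C)n1` has hydrogen in place of isopropyl on an amide-type nitrogen of compound 2 (hydrogen in place of isopropyl on an amide-type nitrogen). Within the data shown here, no pair of measured compounds shows this change. The expected step in this assay is a 1.1-fold lower number from compound 2 to compound 3 (0.05 log units; within the scatter) and so none beyond the scatter in either direction. The estimated value for compound 3 is 6000 nM within an expected range of 2000 nM to 18000 nM for repeated measurements.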

Compound 3, concentration for 50% growth inhibition: "not active" (no number reported)
Compound 3 has no reported number here; no gap can be computed for the estimate.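

In this assay, among these compounds, compound 3 is reported as not active, without a number, so no step from compound 2 can be read. As far as these compounds go, how far swapping isopropyl for hydrogen shifts growth inhibition stays open, and no supporting evidence bears on this result.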